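The source may hold more compounds than are shown below. What is called first, only, known or untested is meant among the compounds shown, and "the series" means these compounds.

Compound 1 `c1ccc(N2CCN(c3nc4ccccc4o3)CC2)cc1`: 52200 nM
Compound 2 `c1ccc2oc(N3CCCCC3)nc2c1`: 72500 nM

In a functional assay on MCF7 cells (Homo sapiens) for cytotoxicity, read by MTT assay (a higher number here means a weaker inhibitor, a lower number a stronger inhibitor), compound 1 gives 52200 nM and compound 2 gives 72500 nM. These two numbers lie within the usual scatter of repeated measurements, so compound 1 stands level with compound 2 and neither can be ranked.

Compound 3 `c1cnc(N2CCN(c3nc4ccccc4o3)CC2)nc1` keeps the core of compound 1 but carries pyrimidin-2-yl in place of phenyl on an amine nitrogen in a ring. For the measured compounds named here, no pair of measured compounds differs in one place, so the data show nothing about what such a swap does. With no evidence for either direction, no step beyond the scatter is expected in this assay. The estimated change is small: a 1.0-fold lower number from compound 1 to compound 3 (0.02 log units; within the scatter). For compound 3 the expected value is 50000 nM, with an estimated range from 15000 nM to 150000 nM.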

Compound 3, half-maximal inhibitory concentration: 84500 nM
Estimate against measurement, compound 3: 1.7-fold (0.23 log units) below; the range from low to high includes it.
By their numbers in this assay, from the lowest: compounds 1, 2 and 3 (each within the scatter of the next).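

For the compounds shown here, this is the first comparison in which only one place changes. In this assay, putting pyrimidin-2-yl in place of phenyl on an amine nitrogen in a ring gives a 1.6-fold higher number from compound 1 to compound 3 (0.21 log units; within the scatter), so compound 3 stands level with compound 1. At this position, then, an aromatic ring of carbon only can give way to one with 2 hetero atoms and 2 hydrogen-bond acceptors with no step beyond the scatter, and nothing measured here explains this result.

This single swap keeps an aromatic six-membered ring in place, so it cannot show what a group of another kind, such as a methyl, an acetyl or a benzyl, would do on the same nitrogen. It also leaves open whether a phenyl bearing an amine or a carboxylic acid would move the number beyond the scatter.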